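This account rests on a few compounds, and the source may have more. Where it says the series, first, only, none or still open, it means among the compounds named here.

Compound 3 `CN1CCN(c2ccc(Nc3ncc4nc(Nc5ccc(F)cc5)n([C@@H]5CCN(C(=O)OC(C)(C)C)C5)c4n3)cc2)CC1` gives 27 nM in a functional assay on HCC827 cells (Homo sapiens) for antiproliferative activity, read by MTT assay, with a stated time of 72 h (a higher number here means a weaker inhibitor, a lower number a stronger inhibitor), the lowest of the three numbers measured. Compound 2 `CN1CCN(c2ccc(Nc3ncc4nc(Nc5ccc(F)cc5)n(CCNS(=O)(=O)C5CC5)c4n3)cc2)CC1` gives 50 nM, and the step of a 1.9-fold lower number from compound 2 to compound 3 (0.27 log units; within the scatter) lies within the scatter. Compound 1 `CN1CCN(c2ccc(Nc3ncc4nc(Nc5ccc(F)cc5)n([C@H]5CCNC5)c4n3)cc2)CC1` gives 1220 nM, far higher: a 45-fold lower number from compound 1 to compound 3 (1.65 log units; beyond the scatter). Compound 4 `CC(=O)Nc1cccc(-n2c(Nc3ccc(F)cc3)nc3cnc(Nc4ccc(N5CCN(C)CC5)cc4)nc32)c1` carries 3-acetamidophenyl in place of 1-(tert-butoxycarbonyl)pyrrolidin-3-yl on an aromatic nitrogen. Among the measured compounds shown here, the steps that bear on this change are a 24-fold lower number from compound 1 to compound 2 (1.39 log units; beyond the scatter) and a 45-fold lower number from compound 1 to compound 3 (1.65 log units; beyond the scatter), both large, while a 1.9-fold lower number from compound 2 to compound 3 (0.27 log units; within the scatter) shows that two quite different larger groups on that aromatic nitrogen give similar numbers. For the measured compounds named here, no measured compound carries an aromatic ring at this position, so the expectation is uncertain. Compound 4 is therefore expected to stay in the same region, with an estimated step of a 1.9-fold higher number from compound 3 to compound 4 (0.27 log units; within the scatter), giving about 50 nM in this assay, between 15 nM and 200 nM.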

Compound 4, half-maximal inhibitory concentration: 10 nM
Estimate against measurement, compound 4: 5.0-fold (0.70 log units) above; the whole stated range lies above it.
By their numbers in this assay, from the lowest: compound 4; then compounds 3 and 2 (each within the scatter of the next); then compound 1.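

In this assay, an aromatic ring on this nitrogen does more than hold the number: 3-acetamidophenyl gives a 2.7-fold lower number from compound 3 to compound 4 (0.43 log units; beyond the scatter) and a 5.0-fold lower number from compound 2 to compound 4 (0.70 log units; beyond the scatter), both modest, and a 120-fold lower number from compound 1 to compound 4 (2.09 log units; beyond the scatter), which is large. The position therefore accepts a six-membered aromatic ring of carbon only, as well as the non-aromatic groups. Nothing measured here explains this gain.

Among the compounds shown here, with only one aromatic example, it remains open whether the gain comes from the ring or from the acetamido group. A plain phenyl, or an amine or carboxylic acid in place of the acetamido group, could separate the two.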